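Working notes: replacing the 5-methoxypyridin-2-yl group

The compounds below may be only part of what the source reports. "The series", "measured", "known", "first", "only" and "open" are said of these compounds alone.

In a functional assay on SiHa cells (Homo sapiens) for antiproliferative activity, read by CCK-8 assay, with a stated time of 72 h (on this read-out lower numbers stand for stronger inhibition and higher numbers for weaker inhibition), compound 1 (`COc1ccc(-c2cncnc2-c2cc(OC)c(OC)c(OC)c2)cc1F`) gives 3340 nM and compound 2 (`COc1ccc(-c2cncnc2-c2cc(OC)c(OC)c(OC)c2)nc1`) gives 1750 nM. Among the compounds with values here, on these two numbers, compound 2 cannot be told apart from compound 1, its only neighbour.

The next structure is compound 3 (`COc1cc(-c2ncncc2-c2ccc(B(O)O)cc2)cc(OC)c1OC`), which differs from compound 2 as follows: a group of 9 heavy atoms (6 carbon, 1 boron, 2 oxygen; one six-membered aromatic ring of carbon only) in place of a group of 8 heavy atoms (6 carbon, 1 nitrogen, 1 oxygen; one six-membered aromatic ring with 1 hetero atom), on an aromatic carbon. The place is an aromatic carbon, ortho to a large group, two atoms from the ring nitrogen. The entering group has 2 hydrogen-bond donors, and the leaving group has 0.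

Within the data shown here, one measured step bears on this place: a 1.9-fold lower number from compound 1 to compound 2 (0.28 log units; within the scatter), with 5-methoxypyridin-2-yl in place of 3-fluoro-4-methoxyphenyl. On the strength of that step, no change beyond the scatter is expected in this assay, in either direction. Among the measured compounds shown here, no measured compound contains boron, so this guide is thin and the range must stay wide.

The expected step is a 1.2-fold lower number from compound 2 to compound 3 (0.07 log units; within the scatter). For compound 3 the estimated value is 1500 nM, with an expected range of 250 nM to 6000 nM.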

Compound 3, half-maximal inhibitory concentration: 17500 nM
The estimate for compound 3 lay 12-fold (1.07 log units) below the measured number; measured number above the stated range.
By their numbers in this assay, from the lowest: compounds 2 and 1 (each within the scatter of the next); then compound 3.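

In this assay, this place does not treat all replacements alike: the earlier pair stayed within the scatter, but a 10-fold higher number from compound 2 to compound 3 (1.00 log units; beyond the scatter) and a 5.2-fold higher number from compound 1 to compound 3 (0.72 log units; beyond the scatter). Within the data shown here, the boron-bearing group of compound 3 is therefore the first group to separate from the others, giving a higher number than both the 5-methoxypyridin-2-yl group of compound 2 and the 3-fluoro-4-methoxyphenyl group of compound 1. Nothing in hand accounts for this step.

The change from compound 2 to compound 3 alters several features at once: the methoxy group and the ring nitrogen leave, while boron and the hydrogen-bond donors enter, so the compounds shown cannot assign the higher number to any one of these features. Also open, as far as these compounds go, is whether the step belongs to the boronic acid itself or to any hydrogen-bond donor on this ring, a question that an unsubstituted phenyl ring and analogues carrying a carboxylic acid, an amine or a hydroxymethyl group in place of the boronic acid could help to settle.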